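Methylation of the hydroxy group: compound 1 to compound 3

The source may hold more compounds than are shown below. What is called first, only, known or untested is meant among the compounds shown, and "the series" means these compounds.

Compound 1 `O=C(Nc1cccc(-n2cc(-c3ccncc3)c(-c3cc(O)cc(Cl)c3)n2)c1)Nc1ccc(Cl)c(C(F)(F)F)c1` is one of two compounds tested so far in a functional assay on UACC-257 cells (Homo sapiens) for inhibition, read by sulforhodamine B assay, with a stated time of 48 h, tested at 100 uM; on this read-out higher numbers stand for a weaker effect at the one concentration tested and lower numbers for a stronger effect; in that assay compound 1 gives -96%, the lower of the two numbers shown, by a gap that is within the scatter. Going by the values given here, its only neighbour is compound 2 `O=C(Nc1cccc(-n2cc(-c3ccncc3)c(-c3cc(O)cc(Cl)c3)n2)c1)Nc1ccc(Cl)c(Cl)c1`, which in this assay gives -92%. Among the compounds with values here, the single step between measured compounds, a number 4 percentage points higher from compound 1 to compound 2 (within the scatter), puts chloro in place of trifluoromethyl on an aromatic carbon, and both compounds show a strong effect at the one concentration tested.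

Compound 3 `COc1cc(Cl)cc(-c2nn(-c3cccc(NC(=O)Nc4ccc(Cl)c(C(F)(F)F)c4)c3)cc2-c2ccncc2)c1` differs from compound 1 at another place: methyl in place of hydrogen on an oxygen on an aromatic ring. Within the data shown here, no measured step touches the hydroxy group, so the step from compound 1 to compound 2 informs this change only by showing that a small exchange elsewhere in the shared core leaves the read-out unmoved. The direction for a methyl on the oxygen is open; a number somewhat higher than that of compound 1 is expected, though the change may also remain within the scatter. Compound 3 is expected to give -80% in this assay, between -100% and -45%, an expected step of a number 16 percentage points higher from compound 1 to compound 3 (beyond the scatter).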

Compound 3, a percentage reported as activity, at one concentration (the size of the read-out at that concentration, not a potency): -86%
Beside the measured number, compound 3's estimate is 6 percentage points above it; the range from low to high includes it.
By their numbers in this assay, from the lowest: compounds 1, 2 and 3 (each within the scatter of the next).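

In this assay, methyl on this oxygen gives a number 10 percentage points higher from compound 1 to compound 3 (within the scatter), so the exchange of hydroxy for methoxy cannot be told apart from the scatter. The earlier step between measured compounds changed a different place and gave no reading at this oxygen; here, with the hydrogen on the oxygen replaced, compound 3 still gives -86% in this assay, so a free hydroxy is not needed for a strong effect at the one concentration tested. Nothing available explains this result, and the data give no reason for it.

A read-out at one concentration leaves open whether compound 1 and compound 3 would differ in the size of their effect at other concentrations, and whether methoxy would read the same way in the core of compound 2. Going by these compounds, how far the position tolerates other change also remains open, for instance an amine or a carboxylic acid in place of the hydroxy, or a longer chain such as ethoxy or propoxy on the oxygen.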